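This account rests on a few compounds, and the source may have more. Where it says the series, first, only, none or still open, it means among the compounds named here.

Working notes on the series. Within the data shown here, in a functional assay on A549 cells (Homo sapiens) for antiproliferative activity, read by sulforhodamine B assay, with a stated time of 48 h (a higher number here means a weaker inhibitor, a lower number a stronger inhibitor), compound 1 (`COc1ccc(/C=C/C(=O)c2ccccc2-c2ccc(OC)c(OC)c2)cc1OC`) gives 8500 nM, the higher of the two numbers measured so far. Compound 2 (`COc1ccc(OC)c(/C=C/C(=O)c2ccccc2-c2ccc(OC)c(OC)c2)c1`) gives 4100 nM. Among the measured compounds shown here, the only measured step is a 2.1-fold lower number from compound 1 to compound 2 (0.32 log units; beyond the scatter), modest in size and just beyond the scatter.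

Compound 3 (`COc1ccc(/C=C/C(=O)c2ccccc2-c2cccc(F)c2)cc1OC`) differs from compound 1 at another place in the molecule: 3-fluorophenyl in place of 3,4-dimethoxyphenyl on an aromatic carbon. The change sits on an aromatic carbon, ortho to a large group, whereas the measured step lies on a double-bonded chain carbon. For the measured compounds named here, no measured step covers this place, so the direction of the change is not established by the data. The step of a 2.1-fold lower number from compound 1 to compound 2 (0.32 log units; beyond the scatter) serves only as a rough guide to size, and it shows that replacing one dimethoxyphenyl pattern can move the number modestly. The central expectation is therefore no shift beyond the scatter, with wide uncertainty on both sides. The expected step is a 1.3-fold lower number from compound 1 to compound 3 (0.12 log units; within the scatter). In this assay, the estimate for compound 3 is 6500 nM, with an expected range of 2000 nM to 20000 nM.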

Compound 3, half-maximal inhibitory concentration: 330 nM
Estimate against measurement, compound 3: 20-fold (1.29 log units) above; measured number outside the range, below it.
By their numbers in this assay, from the lowest: compound 3; then compound 2; then compound 1.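

In this assay the aromatic carbon ortho to a large group is, on the compounds shown, a far more sensitive place than the double-bonded chain carbon: 3-fluorophenyl in place of 3,4-dimethoxyphenyl gives a 26-fold lower number from compound 1 to compound 3 (1.41 log units; beyond the scatter) and counts as large, whereas a 2.1-fold lower number from compound 1 to compound 2 (0.32 log units; beyond the scatter) is modest. The 3,4-dimethoxyphenyl group is therefore not required at this place for a low number, as a group with fewer heavy atoms and no hydrogen-bond acceptors goes with a much stronger result on the core of compound 1. No available evidence accounts for the size of this step.

The single swap removes both methoxy groups and brings in fluorine together, and the compounds shown do not separate these two parts of the change: an unsubstituted phenyl group at this place would be needed to tell them apart. Also open, going by these compounds, are whether the step holds with the 2,5-dimethoxyphenyl group of compound 2 on the chain, and how a chlorophenyl, a cyanophenyl or an aminophenyl group would read at this place.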